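Shortening the saturated chain of compound 1

The compounds below may be only part of what the source reports. "The series", "measured", "known", "first", "only" and "open" are said of these compounds alone.

Compound 1 (`CCCCCCCCCCCCCCCC(=O)N[C@@H](CO)C[C@@H](O)c1ccccc1`) carries a long saturated chain on its carbonyl. In a functional assay on CHO cells (Cricetulus griseus) for inhibition (a higher number here means a weaker inhibitor, a lower number a stronger inhibitor), compound 1 gives > 1000 nM as a limit and not as a number. Compound 1 therefore stands at the weak end of the two measured compounds. In this assay compound 2 (`CCCCCCCCCCCCCC(=O)N[C@@H](CO)C[C@@H](O)c1ccccc1`), whose chain is shorter, gives 70 nM as a true reading. For the measured compounds named here, the one measured step that bears on this change is an at least 14-fold lower number from compound 1 to compound 2 (1.15 log units; beyond the scatter) and it is large.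

Compound 3 (`CCCCCCCCCC(=O)N[C@@H](CO)C[C@@H](O)c1ccccc1`) removes more of the same chain (hydrogen in place of hexyl on a saturated chain carbon, nine bonds along the chain from a carbonyl carbon), with hydrogen in place of hexyl on a saturated chain carbon, nine bonds along the chain from a carbonyl carbon. A single step cannot show whether shortening keeps helping once the chain is cut further than in compound 2. Even so, a large step towards a lower number is expected in this assay on the evidence of compound 2 (70 nM), with wide uncertainty. The expected step is an at least 5.8-fold lower number from compound 1 to compound 3 (0.76 log units; beyond the scatter) and it points to a stronger inhibitor. Compound 3 is estimated at 170 nM with an expected range from 35 nM to 800 nM in this measurement.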

Compound 3, half-maximal inhibitory concentration: 300 nM
The estimate for compound 3 lay 1.8-fold (0.25 log units) below the measured number; low and high end bracket the measured number.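

In this assay, cutting the chain further does not keep lowering the number, and the shorter chain of compound 3 gives up part of what compound 2 gained: a 4.3-fold higher number from compound 2 to compound 3 (0.63 log units; beyond the scatter). Compound 3 still holds an advantage over the longest chain, with an at least 3.3-fold lower number from compound 1 to compound 3 (0.52 log units; beyond the scatter), so compound 2, whose chain length lies between the other two, is the strongest inhibitor of the three. The size of any gain from compound 1 remains a bound and not an exact figure, as the value for compound 1 is a limit: the limit of > 1000 nM in this assay, at which 1 of the 3 values shown sits.

With only three chain lengths shown, the length that gives the lowest number may lie on either side of compound 2, and how steeply the number changes from one length to the next stays open. On these data alone, it also stays open how a still shorter saturated chain, or a chain of similar length carrying an amine or a carboxylic acid, would behave in this assay.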